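This account rests on a few compounds, and the source may have more. Where it says the series, first, only, none or still open, it means among the compounds named here.

In a functional assay on Malme-3M cells (Homo sapiens) for inhibition, read by sulforhodamine B assay, with a stated time of 48 h (a lower number here means that less compound is tolerated, a higher number that more compound is tolerated), compound 3, `COc1ccc(C(=O)/C=C/c2cc(-c3cc(OC)c(OC)c(OC)c3)n[nH]2)cc1OC`, gives 6790 nM, the lowest of the numbers recorded. Compound 2, `COc1ccc(-c2cc(/C=C/C(=O)c3cc(OC)c(OC)c(OC)c3)[nH]n2)cc1OC`, gives 47500 nM, a higher number. For compound 1, `COc1cc(-c2cc(/C=C/C(=O)c3ccc(Cl)c(Cl)c3)[nH]n2)cc(OC)c1OC`, only a limit is recorded, > 100000 nM, as noted in the limit of > 100000 nM in this assay, at which 1 of the 3 values shown sits. Among the measured compounds shown here, the one measured step bears only loosely on the present change: an at least 14-fold lower number from compound 1 to compound 3 (1.16 log units; beyond the scatter). Compound 4, `COc1cc(C(=O)/C=C/c2cc(-c3cc(OC)c(OC)c(OC)c3)n[nH]2)cc(OC)c1OC`, differs from compound 3 by methoxy in place of hydrogen on an aromatic carbon. For the measured compounds named here, no measured step exchanges hydrogen for methoxy on this ring, so the earlier step offers no direct guide, and compound 4 is expected to move little from compound 3, with a 1.2-fold higher number from compound 3 to compound 4 (0.07 log units; within the scatter) likely inside the scatter. The expected value for compound 4 is therefore 8000 nM, with a range from 3000 nM to 25000 nM.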

Compound 4, concentration lethal to 50% of the cells: 8990 nM
Beside the measured number, compound 4's estimate is 1.1-fold (0.05 log units) below it; measured number inside the range.
By their numbers in this assay, from the lowest: compounds 3 and 4 (each within the scatter of the next); then compound 2. At a limit, above all of these: compound 1.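

In this assay, the third methoxy on the ring bound to the carbonyl carbon changes little: a 1.3-fold higher number from compound 3 to compound 4 (0.12 log units; within the scatter). The same exchange on the other aromatic ring counts for more, with a 5.3-fold lower number from compound 2 to compound 4 (0.72 log units; beyond the scatter), so among these compounds the outcome depends on which ring takes the methoxy. Nothing available explains this difference between the two rings.

As far as these compounds go, it remains open whether this position tolerates only methoxy or would give a similar number with a hydroxyl group, an amine or a longer alkoxy chain.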